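Swapping an indole for a methoxyphenyl on a chalcone-like chain

A few compounds are considered here, and "the series" means these few. Any claim that something is new, unique, unknown or untested is made for them only; others in the source may bear on it.

Three compounds share one core, an aryl ketone joined through a double bond to a second aromatic group, with a sulfur-linked arm on the double-bonded carbon. Compound 1 `COc1ccccc1/C=C(/Sc1ccc(C)cc1)C(=O)c1ccc(Cl)cc1` gives 25000 nM in a functional assay on DU-145 cells (Homo sapiens) for inhibition, read by trypan blue exclusion, with a stated time of 96 h; a lower number here means a stronger inhibitor of growth, a higher number a weaker inhibitor of growth. Compound 2 `O=C(/C(=C\c1ccccc1OCc1ccccc1)SCc1ccc(F)cc1)c1ccc(Cl)cc1` gives 1000 nM in this assay. Compound 3 `O=C(/C(=C\c1c[nH]c2ccc(Br)cc12)SCc1ccc(F)cc1)c1ccc(Cl)cc1` gives 50000 nM, the highest of the three numbers; its value sits within the scatter of compound 1, whereas compound 2 lies far lower and clearly apart from it.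

Compound 4 `COc1ccccc1/C=C(/SCc1ccc(F)cc1)C(=O)c1ccc(Cl)cc1` has not been measured. It keeps the sulfur-linked arm of compounds 2 and 3 and differs from compound 3 in one place: 2-methoxyphenyl in place of 5-bromo-1H-indol-3-yl on a double-bonded chain carbon bound to a double-bonded chain carbon. Compound 1 carries the same 2-methoxyphenyl group as compound 4 but a different sulfur-linked arm, and compound 2 carries the same arm as compound 4 with a different group on the double-bonded carbon. Since compound 2 sits far below compound 3 while compound 1 sits close to it, the step from compound 3 to compound 4 is expected to be downward, a 6.3-fold lower number from compound 3 to compound 4 (0.80 log units; beyond the scatter), beyond the scatter but short of the number of compound 2. Compound 4 is therefore expected at about 8000 nM in this assay, with a likely range from 2000 nM to 40000 nM.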

Compound 4, concentration for 50% growth inhibition: 10000 nM
Beside the measured number, compound 4's estimate is 1.3-fold (0.10 log units) below it; measured number inside the range.
By their numbers in this assay, from the lowest: compound 2; then compound 4; then compounds 1 and 3 (each within the scatter of the next).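

Among the compounds shown here, with the 4-fluorobenzyl arm on sulfur held fixed, the group on a double-bonded chain carbon bound to a double-bonded chain carbon can be read on its own for the first time in this assay: there is a 5.0-fold lower number from compound 3 to compound 4 (0.70 log units; beyond the scatter) when 2-methoxyphenyl replaces 5-bromo-1H-indol-3-yl. Within the 2-substituted phenyl series, the oxygen substituent also matters, with a 10-fold higher number from compound 2 to compound 4 (1.00 log units; beyond the scatter) when hydrogen replaces phenyl on a saturated chain carbon bound to an oxygen on an aromatic ring, so the benzyl ether of compound 2 goes with the lower number. The sulfur arm counts as well, though the change there swaps one whole arm for another: the data show a 2.5-fold lower number from compound 1 to compound 4 (0.40 log units; beyond the scatter) when 4-fluorobenzyl replaces 4-methylphenyl on a sulfur.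

The compounds shown do not separate the contribution of the bromine from that of the indole rings, and they leave open how an amine or a longer chain in place of that phenyl on the ether would read in this assay. No measurement here gives a reason for any of these steps.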